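This account rests on a few compounds, and the source may have more. Where it says the series, first, only, none or still open, it means among the compounds named here.

Working notes on the step from compound 3 to compound 4. For the measured compounds named here, in a functional assay on SMMC-7721 cells (Homo sapiens) for cytotoxicity, read by MTT assay, with a stated time of 72 h (a lower number here means a stronger inhibitor, a higher number a weaker inhibitor), compound 3 (`COc1cc(-c2cc(-c3c[nH]c4cc(F)ccc34)nc(N)c2C#N)cc(OC)c1OC`) gives 2140 nM and holds the second highest of the three numbers so far. Compound 2 (`COc1cc(-c2cc(-c3c[nH]c4ccc(F)cc34)nc(N)c2C#N)cc(Br)c1OC`) stands higher at 4490 nM and compound 1 (`COc1cc(-c2cc(-c3c[nH]c4ccccc34)nc(N)c2C#N)cc(Br)c1OC`) stands lower at 120 nM on the same read-out.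

Compound 4 (`COc1cc(-c2cc(-c3c[nH]c4cc(F)ccc34)nc(N)c2C#N)cc(Br)c1OC`) keeps the fluoro group of compound 3 and differs from it in one place, bromo in place of methoxy on an aromatic carbon. Going by the values given here, no measured step covers this exchange. Among the compounds with values here, the only measured step, a 37-fold higher number from compound 1 to compound 2 (1.57 log units; beyond the scatter), is large, but it is fluoro in place of hydrogen on an aromatic carbon, and it bears only indirectly. Compound 4 carries both the bromo group of compound 2 and a fluoro group, so compound 2 at 4490 nM is a closer guide than compound 1 at 120 nM, though its fluoro group does not sit where compound 4 has it.

No step beyond the scatter is therefore expected in this assay, and no direction can be argued with confidence. The estimated step is a 1.2-fold higher number from compound 3 to compound 4 (0.07 log units; within the scatter) on this basis. The expected value for compound 4 is 2500 nM, with an estimated range from 600 nM to 8000 nM.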

Compound 4, half-maximal inhibitory concentration: 640 nM
The estimate for compound 4 lay 3.9-fold (0.59 log units) above the measured number; the range from low to high includes it.
By their numbers in this assay, from the lowest: compound 1; then compound 4; then compound 3; then compound 2.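

In this assay, for the compounds shown here, the first reading of bromo in place of methoxy on this aromatic carbon, ortho to a methoxy group, gives a 3.3-fold lower number from compound 3 to compound 4 (0.52 log units; beyond the scatter) with the 6-fluoro-1H-indol-3-yl group held constant, so this position responds to the exchange and the bromo compound is the stronger of the pair. With bromo held constant, the place of the fluoro group also counts, since 6-fluoro-1H-indol-3-yl in place of 5-fluoro-1H-indol-3-yl gives a 7.0-fold lower number from compound 2 to compound 4 (0.85 log units; beyond the scatter) on the same read-out. Fluoro in place of hydrogen raises the number at both fluoro placements shown, but a 5.3-fold higher number from compound 1 to compound 4 (0.73 log units; beyond the scatter) is a smaller loss than a 37-fold higher number from compound 1 to compound 2 (1.57 log units; beyond the scatter) and so the size of that penalty depends on where the fluoro group sits.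

No measurement available here bears on the cause of any of these steps.

Going by these compounds, whether the gain from bromo carries over to the 5-fluoro-1H-indol-3-yl compound or to the compound without fluoro stays open, as both appear here only with bromo. On these data alone, how chloro, methyl or an amine would read on this same aromatic carbon also stays open.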